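A few compounds are considered here, and "the series" means these few. Any claim that something is new, unique, unknown or untested is made for them only; others in the source may bear on it.

In a functional assay on HCT-116 cells (Homo sapiens) for inhibition, read by CCK-8 assay, with a stated time of 48 h (a lower number here means a stronger inhibitor, a higher number a weaker inhibitor), compound 1 (`CCN1CCN(C(=S)SCC(=O)N(Cc2ccc(OC)cc2)c2cc(OC)c(OC)c(OC)c2)CC1`) gives 7700 nM. Compound 2 (`COc1ccc(CN(C(=O)CN2CCN(C(C)=O)CC2)c2cc(OC)c(OC)c(OC)c2)cc1`) gives > 20000 nM, which is a limit of the assay and not a number. Compound 3 (`COc1cc(N(Cc2ccc(Cl)cc2)C(=O)CSC(=S)N2CCN(C(=O)OC(C)(C)C)CC2)cc(OC)c1OC`) gives 8490 nM, and compound 1 at 7700 nM lies within the scatter of it, so these two values cannot be ranked.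

Next is compound 4 (`COc1cc(N(Cc2ccc(C)cc2)C(=O)CSC(=S)N2CCN(C(=O)OC(C)(C)C)CC2)cc(OC)c1OC`), which differs from compound 3 by methyl in place of chloro on an aromatic carbon. This is methyl in place of chloro on an aromatic carbon, para to a large group, or 4-chlorobenzyl to 4-methylbenzyl.

For the measured compounds named here, the only measured step, an at least 2.5-fold higher number from compound 1 to compound 2 (0.41 log units; beyond the scatter), changes a group on a saturated chain carbon bound to a carbonyl carbon. It does not touch the aromatic carbon in question, so it gives no size for this exchange. Going by the values given here, no measured step covers a change at that place. No step beyond the scatter is therefore expected in this assay, in either direction, and the expectation stays anchored on compound 3 at 8490 nM. The expected size is a 1.1-fold lower number from compound 3 to compound 4 (0.03 log units; within the scatter). For compound 4 the estimated value is 8000 nM, with an expected range of 3500 nM to 17000 nM.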

Compound 4, half-maximal inhibitory concentration: > 20000 nM
Compound 4 ended at the assay's limit; the forecaster's own chance of this, stated with the estimate: 8%; middle value at least 2.5-fold (0.39 log units) away from the limit.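

In this assay, the exchange of chloro for methyl on the aromatic carbon, para to a large group, gives an at least 2.3-fold higher number from compound 3 to compound 4 (0.37 log units; beyond the scatter), so this position responds to a change that leaves heavy-atom count, hydrogen-bond donors, hydrogen-bond acceptors and net charge the same; those counts therefore do not separate the two groups. Compound 4 gives > 20000 nM, which is a limit of the assay and not a number. The step is therefore a lower bound, and its full size cannot be read because compound 4 sits at that limit: the limit of > 20000 nM in this assay, at which 2 of the 4 values shown sit.

On these data alone, it remains open whether a measurable value at this place is particular to chloro or would also be seen with fluoro, bromo, trifluoromethyl or a nitrile. As far as these compounds go, it also remains open whether the same chloro-to-methyl exchange would give a step of this kind when the rest of the molecule differs from compound 3.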